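The source may hold more compounds than are shown below. What is called first, only, known or untested is meant among the compounds shown, and "the series" means these compounds.

Measured in a functional assay on HeLa cells (Homo sapiens) for inhibition, read by MTT assay, with a stated time of 72 h; a lower number here means a stronger inhibitor, a higher number a weaker inhibitor:
- compound 1 `COc1ccc(/C=C/C(=O)c2c(O)cc(O)cc2OC)cc1OC`: 49500 nM
- compound 2 `COc1cc(/C=C/C(=O)c2c(O)cc(O)cc2OC)cc(OC)c1`: 13300 nM

Compound 2 holds the lower number of the two at 13300 nM, and compound 1 gives 49500 nM. The gap between these two compounds lies beyond the scatter. Compound 3 `COc1cc(/C=C/C(=O)c2c(O)cc(O)cc2OC)cc(OC)c1OC` carries methoxy in place of hydrogen on an aromatic carbon of compound 2, ortho to two methoxy groups and para to a large group (methoxy in place of hydrogen on an aromatic carbon). Among the measured compounds shown here, no measured pair shows this change, so the expectation is loose: a modest move toward a lower number in this assay, perhaps not beyond the scatter. The estimated step is a 1.5-fold lower number from compound 2 to compound 3 (0.17 log units; within the scatter). For compound 3 the estimated value is 9000 nM, with an expected range of 2500 nM to 30000 nM.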

Compound 3, half-maximal inhibitory concentration: 18900 nM
Estimate against measurement, compound 3: 2.1-fold (0.32 log units) below, and the stated range covers the measured number.
By their numbers in this assay, from the lowest: compounds 2 and 3 (each within the scatter of the next); then compound 1.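

In this assay, methoxy in place of hydrogen on the aromatic carbon ortho to two methoxy groups and para to a large group gives a 1.4-fold higher number from compound 2 to compound 3 (0.15 log units; within the scatter), so filling this carbon with methoxy leaves compound 3 level with compound 2. The same kind of exchange on another aromatic carbon gives a 2.6-fold lower number from compound 1 to compound 3 (0.42 log units; beyond the scatter), so the size of the step depends on which carbon receives the methoxy in these compounds. Nothing available here accounts for either step. As far as these compounds go, whether an amine or a longer alkoxy chain on this carbon would give a different number remains open.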